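This account rests on a few compounds, and the source may have more. Where it says the series, first, only, none or still open, it means among the compounds named here.

Measured so far in a functional assay on CCRF-CEM cells (Homo sapiens) for inhibition; a higher number here means that more compound is tolerated, a lower number that less compound is tolerated: compound 1 `O=C(OCOCN1c2ccccc2C(=O)N(Cc2ccccc2)S1(=O)=O)c1ccccc1` gives 100000 nM; compound 2 `O=C1c2ccccc2N(Cc2ccccc2)S(=O)(=O)N1Cc1ccccc1` gives 108000 nM; compound 3 `O=C1c2ccccc2N(Cc2ccc(Cl)c(Cl)c2)S(=O)(=O)N1Cc1ccccc1` gives 16400 nM.

Compound 3 stands lowest of the three numbers in this assay, with compound 1 nearest and compound 2 furthest, both beyond the scatter. Within the data shown here, the only single-point step, a 6.6-fold lower number from compound 2 to compound 3 (0.82 log units; beyond the scatter), shows that the 3,4-dichlorophenyl lowers the number against plain phenyl. Compound 4 `C#CCOCN1c2ccccc2C(=O)N(Cc2ccccc2)S1(=O)=O` goes the other way: propargyloxy in place of 3,4-dichlorophenyl on a saturated chain carbon bound to a sulfonamide nitrogen in a ring. That removes the group which gave the only modest lowering in the series, and compound 1, which also carries no aryl on that chain carbon, sits at 100000 nM. The expected step is therefore upward, a 4.9-fold higher number from compound 3 to compound 4 (0.69 log units; beyond the scatter), back toward the values of compounds 1 and 2. Compound 4 is estimated at 80000 nM, range 30000 nM to 200000 nM.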

Compound 4, half-maximal cytotoxic concentration: 23000 nM
Compound 4: middle estimate off by 3.5-fold (0.54 log units), on the high side; the whole stated range lies above it.
By their numbers in this assay, from the lowest: compounds 3 and 4 (each within the scatter of the next); then compounds 1 and 2 (each within the scatter of the next).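

In this assay the step of a 1.4-fold higher number from compound 3 to compound 4 (0.15 log units; within the scatter) shows that an aryl group on this chain carbon is not needed for the lower number, since propargyloxy and 3,4-dichlorophenyl cannot be told apart here. The step of a 4.7-fold lower number from compound 2 to compound 4 (0.67 log units; beyond the scatter) sets propargyloxy apart from phenyl at the same place, and the step of a 4.3-fold lower number from compound 1 to compound 4 (0.64 log units; beyond the scatter) shows that the end of the arm counts, with ethynyl in place of benzoyloxy. No measurement offered here explains these steps.

Open: whether an amine, a carboxylic acid or a longer chain at this carbon would keep the lower number.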